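Notes on the step from compound 3 to compound 4

The source may report more compounds than this note shows. Statements on the series, on what has been measured and on what is new or still open speak of the compounds shown alone.

Values in an ADME assay on HEK293 cells (Homo sapiens) for cytotoxicity, read by CCK-8 assay, with a stated time of 48 h; a higher number here means a weaker inhibitor, a lower number a stronger inhibitor:
- compound 1 `COc1ccc(/C=C\c2cc(OC)c(OC)c(OC)c2)cc1OCc1ccc(CNC(C)(C)C(=O)O)cc1`: > 50000 nM (a limit of the assay, not a number)
- compound 2 `COc1ccc(/C=C\c2cc(OC)c(OC)c(OC)c2)cc1OCc1ccc(C=O)cc1`: 46000 nM
- compound 3 `COc1ccc(/C=C\c2cc(OC)c(OC)c(OC)c2)cc1OCc1ccc(CO)cc1`: 37000 nM

Among the compounds with values here, compound 3 gives 37000 nM and cannot be separated from the only other number, as the comparison shows a 1.2-fold lower number from compound 2 to compound 3 (0.09 log units; within the scatter). Compound 4 `COc1ccc(/C=C\c2cc(OC)c(OC)c(OC)c2)cc1OCc1ccc(CN2CC[C@@H](C(=O)O)C2)cc1` is still to be measured. It carries 3-carboxypyrrolidin-1-yl in place of hydroxy on a saturated chain carbon bound to an aromatic carbon.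

The closest measured case is compound 1, which carries (1-carboxy-1-methylethyl)amino at that place. Its step runs the opposite way and is only a floor, set by a limit: an at least 1.3-fold lower number from compound 1 to compound 3 (0.13 log units; that floor lies within the scatter). The other step from compound 1 is also a floor: an at least 1.0-fold lower number from compound 1 to compound 2 (0.03 log units; that floor lies within the scatter). Neither step shows a change beyond the scatter, but neither rules one out. A small move towards a higher number is therefore expected, and a report as a limit alone is quite possible.

The expected step is a 1.4-fold higher number from compound 3 to compound 4 (0.13 log units; within the scatter). For compound 4 the estimate is 50000 nM, with an expected range of 25000 nM to 100000 nM.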

Compound 4, half-maximal inhibitory concentration: 27000 nM
The estimate for compound 4 lay 1.9-fold (0.27 log units) above the measured number, within the range that was stated.
By their numbers in this assay, from the lowest: compounds 4, 3 and 2 (each within the scatter of the next). At a limit, above all of these: compound 1.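

In this assay, a much larger group at this place, on a saturated chain carbon bound to an aromatic carbon, leaves the reading within the scatter: a 1.4-fold lower number from compound 3 to compound 4 (0.14 log units; within the scatter), and a 1.7-fold lower number from compound 2 to compound 4 (0.23 log units; within the scatter). Compound 1 also carries a carboxylic acid in its group at this place but is reported only as a limit of the assay, whereas compound 4, with 3-carboxypyrrolidin-1-yl, gives a number: the limit of > 50000 nM in this assay, at which 1 of the 4 values shown sits. The step of an at least 1.8-fold lower number from compound 1 to compound 4 (0.26 log units; that floor lies within the scatter) is only a floor, and it does not separate (1-carboxy-1-methylethyl)amino from 3-carboxypyrrolidin-1-yl.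

The compounds shown leave open whether the ring amine or the carboxylic acid of 3-carboxypyrrolidin-1-yl matters to this reading, which a plain pyrrolidin-1-yl or the methyl ester of the acid would address. From the compounds shown here alone, the opposite configuration at the defined stereocentre and a six-membered piperidine ring carrying the same carboxylic acid also remain open.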